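Phenyl in place of morpholin-4-yl at the amidine-like carbon

This account rests on a few compounds, and the source may have more. Where it says the series, first, only, none or still open, it means among the compounds named here.

Compound 1 `O=C(CC1c2ccccc2N=C(N2CCCCC2)N1c1ccccc1)NCc1ccccc1` gives 77% in a functional assay on cells (Oocyte) for inhibition of Voltage-dependent T-type calcium channel subunit alpha-1H (Homo sapiens), tested at 100 uM; a higher number here means more inhibition at the concentration tested (going by the name of the read-out), a lower number less inhibition. Compound 2 `O=C(CC1c2ccccc2N=C(N2CCOCC2)N1c1ccccc1)NCc1ccccc1` gives 63.8% there, the lower of the two values, with a number 13.2 percentage points lower from compound 1 to compound 2 (beyond the scatter). Compound 3 `O=C(CC1c2ccccc2N=C(c2ccccc2)N1c1ccccc1)NCc1ccccc1` follows from compound 2 by phenyl in place of morpholin-4-yl on a carbon with a double bond to nitrogen. Within the data shown here, only one measured step bears on it: the change at the same carbon from compound 1 to compound 2, a modest loss. Among the measured compounds shown here, no measured step introduces phenyl, so the direction is open; a step of similar modest size either way is plausible. Compound 3 is estimated at 66%, range 42% to 86%, meaning an expected a number 2.2 percentage points higher from compound 2 to compound 3 (within the scatter).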

Compound 3, a percentage reported as inhibition, at one concentration (the size of the read-out at that concentration, not a potency): 14.8%
Beside the measured number, compound 3's estimate is 51.2 percentage points above it; measured number below the stated range.
By their numbers in this assay, from the lowest: compound 3; then compound 2; then compound 1.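

In this assay, this carbon is far more sensitive to the change of group than the swap between the two saturated rings had shown: phenyl gives a number 49 percentage points lower from compound 2 to compound 3 (beyond the scatter) and a number 62.2 percentage points lower from compound 1 to compound 3 (beyond the scatter). Both compounds with a ring attached through nitrogen, compound 1 and compound 2, keep much more inhibition than compound 3, whose aromatic ring is carbon only. No evidence here explains the loss. Still open, on these data alone, is whether an open-chain amine such as dimethylamino retains inhibition at this carbon, and whether a pyridyl ring behaves like phenyl.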